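One Added Methoxy in a Level Series

This account rests on a few compounds, and the source may have more. Where it says the series, first, only, none or still open, it means among the compounds named here.

In a functional assay on HeLa cells (Homo sapiens) for antiproliferative activity, read by sulforhodamine B assay, with a stated time of 48 h (on this read-out lower numbers stand for stronger inhibition and higher numbers for weaker inhibition), compound 2 (`COc1ccc2nc(-c3ccc(N/C=C\C(=O)c4ccc(OC)c([N+](=O)[O-])c4)cc3)sc2c1`) gives 17600 nM and stands level with compound 3 (`COc1ccc2nc(-c3ccc(N/C=C\C(=O)c4ccc(OC)c([N+](=O)[O-])c4)c(C)c3)sc2c1`) at 17600 nM as measured. Compound 1 (`COc1ccc2nc(-c3ccc(N/C=C\C(=O)c4cc(OC)c(OC)c(OC)c4)cc3)sc2c1`) gives 14100 nM and lies within the scatter of both. Compound 4 (`COc1ccc2nc(-c3ccc(N/C=C\C(=O)c4cc(OC)c(OC)c([N+](=O)[O-])c4)cc3)sc2c1`) follows from compound 2 by a single change (methoxy in place of hydrogen on an aromatic carbon). Among the compounds with values here, the only measured step in one place, methyl in place of hydrogen on an aromatic carbon, is no change at the digits printed from compound 2 to compound 3 (within the scatter) and involves a different group, so it offers limited guidance. No shift beyond the scatter is therefore expected in this assay for the new methoxy. The expected step is a 1.2-fold lower number from compound 2 to compound 4 (0.07 log units; within the scatter) and stays small. For compound 4 the estimated value is 15000 nM (expected range 7000 nM to 30000 nM).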

Compound 4, half-maximal inhibitory concentration: 16100 nM
Compound 4: middle estimate off by 1.1-fold (0.03 log units), on the low side, within the range that was stated.
By their numbers in this assay, from the lowest: compounds 1, 4, 2 and 3 (each within the scatter of the next).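

In this assay, methoxy in place of hydrogen on this aromatic carbon, ortho to a methoxy group and meta to a nitro group, gives a 1.1-fold lower number from compound 2 to compound 4 (0.04 log units; within the scatter), so the position takes this added group with no shift beyond the scatter. Nitro in place of methoxy on an aromatic carbon gives a 1.1-fold higher number from compound 1 to compound 4 (0.06 log units; within the scatter), which also stays within the scatter. No supporting measurement bears on either step. The compounds shown leave open whether an amine or a carboxylic acid at this position, or a longer chain such as ethoxy, would move the number beyond the scatter.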